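The source may hold more compounds than are shown below. What is called first, only, known or untested is meant among the compounds shown, and "the series" means these compounds.

Within the data shown here, compound 2 `COC(=O)C1=C(C)NC(=O)N(C(=O)NCCCN2CCN(c3cccc([N+](=O)[O-])c3)CC2)C1c1ccc(F)c(F)c1` has the highest number of the two so far in an assay on liver for binding affinity to Alpha-1B adrenergic receptor (Homo sapiens), using microsomes (on this read-out lower numbers stand for stronger inhibition and higher numbers for weaker inhibition), giving 150 nM; its neighbour compound 1 `COC(=O)C1=C(C)NC(=O)N(C(=O)NCCCN2CCN(c3ccc(Cl)cc3)CC2)C1c1ccc(F)c(F)c1` gives 17 nM. The step of an 8.8-fold higher number from compound 1 to compound 2 (0.95 log units; beyond the scatter) is the only measured one. Compound 3 `COC(=O)C1=C(C)NC(=O)N(C(=O)NCCCN2CCN(c3ccccc3Cl)CC2)C1c1ccc(F)c(F)c1` is made from compound 2 by 2-chlorophenyl in place of 3-nitrophenyl on an amine nitrogen in a ring. The change returns a chlorophenyl group, which in compound 1 went with the lower number, so compound 3 is expected to show a step of a 3.8-fold lower number from compound 2 to compound 3 (0.57 log units; beyond the scatter) downward, though the chlorophenyl differs from that of compound 1, and the estimate is wide. Compound 3 is expected at 40 nM, between 10 nM and 160 nM.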

Compound 3, inhibition constant: 15 nM
For compound 3 the middle estimate is 2.7-fold (0.43 log units) above the measured one; the measured number falls inside the stated range.
By their numbers in this assay, from the lowest: compounds 3 and 1 (each within the scatter of the next); then compound 2.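

In this assay, 2-chlorophenyl in place of 3-nitrophenyl on the amine nitrogen in a ring gives a 10-fold lower number from compound 2 to compound 3 (1.00 log units; beyond the scatter), so the group at this place can shift the number well beyond the scatter. Among these compounds, the two chlorophenyl groups read alike, with a 1.1-fold lower number from compound 1 to compound 3 (0.05 log units; within the scatter), and the earlier compounds could not show this. Nothing measured here accounts for either result. The compounds shown cannot tell whether the nitro group itself or where it sits goes with the higher number of compound 2. From the compounds shown here alone, how 3-chlorophenyl or 2-methoxyphenyl would read on that nitrogen stays open.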